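Swapping the aryl group on compound 3 for a 3-ethylphenyl

A few compounds are considered here, and "the series" means these few. Any claim that something is new, unique, unknown or untested is made for them only; others in the source may bear on it.

Measured so far:
- compound 1, `COc1cc(NC(=O)Nc2cc(Nc3ccc(C(C)(C)C)cc3)ncn2)cc(OC)c1`, gives 17.5% in a functional assay on NCI-H520 cells (Homo sapiens) for inhibition, read by MTT assay, with a stated time of 48 h, tested at 10 uM; a higher number here means more inhibition at the concentration tested (going by the name of the read-out), a lower number less inhibition
- compound 2, `COc1cc(NC(=O)Nc2cc(Nc3ccc(C)c(C)c3)ncn2)cc(OC)c1`, gives 29.5%
- compound 3, `COc1cc(NC(=O)Nc2cc(Nc3ccc(C)c(F)c3)ncn2)cc(OC)c1`, gives 30.6%

Compound 3 sits at the top of these three numbers, though its gap to compound 2 is within the scatter; only compound 1 lies clearly lower. The two steps that do stand out are a number 12 percentage points higher from compound 1 to compound 2 (beyond the scatter) and a number 13.1 percentage points higher from compound 1 to compound 3 (beyond the scatter), both a change of the aryl group on the nitrogen on an aromatic ring. The step of a number 1.1 percentage points higher from compound 2 to compound 3 (within the scatter), a swap of one small substituent on the aromatic carbon, made no real difference.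

Compound 4, `CCc1cccc(Nc2cc(NC(=O)Nc3cc(OC)cc(OC)c3)ncn2)c1`, has not been measured. Its change from compound 3 is 3-ethylphenyl in place of 3-fluoro-4-methylphenyl on a nitrogen on an aromatic ring. Among the measured steps, the 1>2 and 1>3 steps bear on it, since both alter the same aryl group; the 2>3 step shows the smaller rearrangements on that ring leave the number alone. The leaving and entering groups have the same count of heavy atoms, so the account expects a step of a number 3.6 percentage points lower from compound 3 to compound 4 (within the scatter), none beyond the scatter. Compound 4 is therefore estimated at 27%, ranging from 12% to 42%.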

Compound 4, a percentage reported as inhibition, at one concentration (the size of the read-out at that concentration, not a potency): 23%
Estimate against measurement, compound 4: 4 percentage points above; the range from low to high includes it.
By their numbers in this assay, from the lowest: compounds 1, 4, 2 and 3 (each within the scatter of the next, the first and the last beyond it).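

In this assay the 3-ethylphenyl group on this nitrogen cannot be separated from any of the three aryl groups seen earlier (a number 7.6 percentage points lower from compound 3 to compound 4 (within the scatter); a number 6.5 percentage points lower from compound 2 to compound 4 (within the scatter); a number 5.5 percentage points higher from compound 1 to compound 4 (within the scatter)). The earlier compounds shown here split into two levels, with 4-(tert-butyl)phenyl clearly apart from the other two aryl groups, but compound 4 lies within the scatter of both levels, so the change to 3-ethylphenyl does not settle which level it belongs to. Nothing available explains why these aryl groups give such close numbers.

On these data alone, it remains open whether an aryl group carrying an amine, a carboxylic acid or a longer chain such as butyl would move the number clear of this narrow band. As far as these compounds go, the effect of replacing this aryl group with a non-aromatic ring such as cyclohexyl also remains open.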